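The source may report more compounds than this note shows. Statements on the series, on what has been measured and on what is new or still open speak of the compounds shown alone.

Compound 1 `CC1(C)CCCN(CC2(O)CCN(CCCc3c[nH]c4ccc(-n5cnnc5)cc34)CC2)C1`: 0.65 nM
Compound 2 `Cc1ccccc1CN(C)CC1(O)CCN(CCCc2c[nH]c3ccc(-n4cnnc4)cc23)CC1`: 1.3 nM

In an assay on CHO cells with 5-hydroxytryptamine receptor 1D (Homo sapiens) as the target (a higher number here means a weaker inhibitor, a lower number a stronger inhibitor), compound 1 gives 0.65 nM, the lowest of the two numbers shown, while compound 2 gives 1.3 nM. The step of a 2.0-fold higher number from compound 1 to compound 2 (0.30 log units; within the scatter) is the only measured one that bears on the change to compound 3 `CN(Cc1ccccc1)CC1(O)CCN(CCCc2c[nH]c3ccc(-n4cnnc4)cc23)CC1`, which is benzyl(methyl)amino in place of 3,3-dimethylpiperidin-1-yl on a saturated chain carbon bound to a saturated ring carbon. Since compound 3 shares the benzyl(methyl)amino pattern of compound 2, a comparably small step is expected in this assay, a 1.8-fold higher number from compound 1 to compound 3 (0.27 log units; within the scatter), with no difference beyond the scatter. Compound 3 is therefore estimated at 1.2 nM, between 0.5 nM and 3.5 nM.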

Compound 3, half-maximal inhibitory concentration: 1.2 nM
Estimate against measurement, compound 3: no gap at the digits printed; low and high end bracket the measured number.
By their numbers in this assay, from the lowest: compounds 1, 3 and 2 (each within the scatter of the next).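

In this assay the step of a 1.8-fold higher number from compound 1 to compound 3 (0.27 log units; within the scatter) shows that benzyl(methyl)amino, without the methyl on an aromatic carbon that compound 2 carries, stays within the scatter of 3,3-dimethylpiperidin-1-yl on a saturated chain carbon bound to a saturated ring carbon. The step of a 1.1-fold lower number from compound 2 to compound 3 (0.03 log units; within the scatter) adds that hydrogen in place of methyl on an aromatic carbon makes no difference beyond the scatter. No evidence is at hand that would explain either step.

From the compounds shown here alone, whether a methoxy group in place of that hydrogen, or a phenethyl group in place of the benzyl, would give a step beyond the scatter remains open.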